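A few compounds are considered here, and "the series" means these few. Any claim that something is new, unique, unknown or untested is made for them only; others in the source may bear on it.

Measured so far in a functional assay on MDA-MB-231 cells (Homo sapiens) for antiproliferative activity, read by MTT assay, with a stated time of 48 h; on this read-out higher numbers stand for weaker inhibition and lower numbers for stronger inhibition:

compound 1 `O=C(/C=C/c1ccccc1)Nc1cc2ncnc(Nc3ccc(F)c(Cl)c3)c2s1` gives 2100 nM
compound 2 `C#Cc1cccc(Nc2ncnc3sc(NC(=O)/C=C/c4ccccc4)cc23)c1` gives 5050 nM
compound 3 `O=C(/C=C/c1ccccc1)Nc1cc2c(Nc3ccc(F)c(Cl)c3)ncnc2s1` gives 7600 nM

Compound 3 has the highest number of the three. Its nearest neighbour is compound 2, whose number is lower by a 1.5-fold higher number from compound 2 to compound 3 (0.18 log units; within the scatter), a step that comes from putting 3-chloro-4-fluorophenyl in place of 3-ethynylphenyl on a nitrogen on an aromatic ring. Compound 1 shows a lower number than compound 3, and that gap lies beyond the scatter.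

The next compound, compound 4 `O=C(/C=C/c1ccccc1)Nc1cc2c(Nc3ccc(Cl)c(Cl)c3)ncnc2s1`, differs from compound 3 only by chloro in place of fluoro on an aromatic carbon. Among the measured compounds shown here, no measured step involves a chloro in place of fluoro, so the only guide is the general observation that the one step changing the group on the amine nitrogen, from compound 2 to compound 3, stayed within the scatter. On this basis the step from compound 3 to compound 4 in this assay is expected to be a 1.3-fold lower number from compound 3 to compound 4 (0.10 log units; within the scatter), with no change beyond the scatter foreseen. Compound 4 is therefore estimated at 6000 nM, in a range from 2500 nM to 15000 nM.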

Compound 4, half-maximal inhibitory concentration: 4400 nM
Estimate against measurement, compound 4: 1.4-fold (0.13 log units) above; the range from low to high includes it.
By their numbers in this assay, from the lowest: compound 1; then compounds 4, 2 and 3 (each within the scatter of the next).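

In this assay the one exchange of halogens shown, chloro in place of fluoro on an aromatic carbon ortho to a chloro group and para to a large group, gives a 1.7-fold lower number from compound 3 to compound 4 (0.24 log units; within the scatter) and so stays within the scatter, which means this assay does not separate these two atoms at this position. The 3,4-dichlorophenyl group likewise cannot be told apart from 3-ethynylphenyl on the same nitrogen, with a 1.1-fold lower number from compound 2 to compound 4 (0.06 log units; within the scatter) also lying within the scatter. No measurement at hand bears on what lies behind these numbers.

From the compounds shown here alone, it remains open whether a group other than a halogen at this position, such as a methoxy, an amine or a carboxylic acid, would move the number beyond the scatter. Going by these compounds, it is also open whether 3,4-dichlorophenyl would behave the same way on the core of compound 1.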